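Chloro to trifluoromethyl on the biaryl of compound 1

A few compounds are considered here, and "the series" means these few. Any claim that something is new, unique, unknown or untested is made for them only; others in the source may bear on it.

Measured:
compound 1 `O=C1c2ccc(OCc3cccc(-c4ccc(Cl)cc4F)c3)cc2CN1C1CCCC1` — > 5000 nM
compound 2 `O=C(O)c1cc(-c2cccc(COc3ccc4c(=O)n(CC5CC5)sc4c3)c2)ccc1Cl` — 2480 nM

In an assay on HEK293 cells for positive allosteric modulation of metabotropic glutamate receptor 2 (Rattus norvegicus), read by thallium flux (a higher number here means that more compound is needed for the effect, a lower number that less compound is needed), compound 1 gives only a limit, > 5000 nM, a limit of the assay and not a number. In this assay compound 2 gives 2480 nM. Compound 3 `O=C1c2ccc(OCc3cccc(-c4ccc(C(F)(F)F)cc4F)c3)cc2CN1C1CCCC1` differs from compound 1 by trifluoromethyl in place of chloro on an aromatic carbon. Within the data shown here, no measured pair carries this same change, so no step size is known; since compound 1 sits at the limit of > 5000 nM in this assay, at which 1 of the 2 values shown sits, the step cannot be placed in either direction beyond the usual scatter. Compound 3 is expected at 5000 nM, range 1500 nM to 20000 nM. The expected step is a number no higher from compound 1 to compound 3 (the limit leaves the size open).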

Compound 3, half-maximal effective concentration: > 5000 nM
Compound 3: a limit, no number (the forecaster's own chance of this, stated with the estimate: 50%); the middle value sits exactly at the limit.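

Compound 1 and compound 3 both stand at a limit of this assay, not at a number, so no step between them can be read: the limit of > 5000 nM in this assay, at which 2 of the 3 values shown sit.

Going by these compounds, whether trifluoromethyl in place of chloro changes the amount of compound needed remains open.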